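The source may report more compounds than this note shows. Statements on the series, on what has been measured and on what is new or still open speak of the compounds shown alone.

Notes on the series. In an ADME assay on THP-1 cells (Homo sapiens) for cytotoxicity (on this read-out higher numbers stand for weaker inhibition and lower numbers for stronger inhibition), compound 3 `COc1ccccc1-c1nnc(-c2ccc(C(=O)N/N=C/c3ccc(O)cc3O)cc2)o1` gives 104000 nM; compound 1 `COc1ccccc1-c1nnc(-c2ccc(C(=O)N/N=C/c3ccc(O)c(O)c3)cc2)o1` gives 100000 nM, within the scatter of compound 3, while compound 2 `COc1ccccc1-c1nnc(-c2ccc(C(=O)N/N=C/c3c(O)cc(O)cc3O)cc2)o1` gives 12400 nM, well below both. Compound 4 `COc1ccccc1-c1nnc(-c2ccc(C(=O)N/N=C/c3ccc(O)cc3)cc2)o1` differs from compound 3 by hydrogen in place of hydroxy on an aromatic carbon, the hydroxy removed sitting ortho to a large group and meta to the remaining hydroxy. Among the measured compounds shown here, the one step of the same kind, an 8.4-fold higher number from compound 2 to compound 3 (0.92 log units; beyond the scatter), raised the number; the shift of hydroxy positions, a 1.0-fold higher number from compound 1 to compound 3 (0.02 log units; within the scatter), did not. As compound 3 already stands at the high end of this assay, compound 4 is expected to move a 1.3-fold higher number from compound 3 to compound 4 (0.10 log units; within the scatter) at most, giving an estimated 130000 nM with a range of 50000 nM to 350000 nM.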

Compound 4, half-maximal inhibitory concentration: 261000 nM
Compound 4: middle estimate off by 2.0-fold (0.30 log units), on the low side, and the stated range covers the measured number.
By their numbers in this assay, from the lowest: compound 2; then compounds 1 and 3 (each within the scatter of the next); then compound 4.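

Notes on the result. In this assay, hydrogen in place of the hydroxy ortho to a large group still raises the number from the high end of the series (a 2.5-fold higher number from compound 3 to compound 4 (0.40 log units; beyond the scatter)), and the wider change to 4-hydroxyphenyl gives the largest step here (a 21-fold higher number from compound 2 to compound 4 (1.32 log units; beyond the scatter)). Each loss of a hydroxy shown raises the number (a 2.6-fold higher number from compound 1 to compound 4 (0.42 log units; beyond the scatter)). The size of that rise depends on the starting compound: the same change on two cores in this assay, an 8.4-fold higher number (0.92 log units; beyond the scatter) from compound 2 to compound 3 and a 2.6-fold higher number (0.42 log units; beyond the scatter) from compound 1 to compound 4, 3.2-fold (0.51 log units) apart, beyond the scatter of two such steps.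

Still open, as far as these compounds go, is how an amine or a carboxylic acid in place of this hydroxy would read. Also open, from the compounds shown here alone, is where plain phenyl, with no hydroxy left, would fall.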